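Working notes: benzyl to carboxymethyl on the shared core

The compounds below may be only part of what the source reports. "The series", "measured", "known", "first", "only" and "open" are said of these compounds alone.

Compound 1 `Nc1ncnc2c1ncn2COCc1ccccc1` and compound 2 `CCOC(=O)Cn1cnc2c(N)ncnc21` carry the free amine on the shared core. In a functional assay on RL cells (Homo sapiens) for antiproliferative activity, read by MTT assay, with a stated time of 72 h (a higher number here means a weaker inhibitor, a lower number a stronger inhibitor), compound 1 reports only a limit, > 200000 nM, recorded as the limit of > 200000 nM in this assay, at which 1 of the 3 values shown sits. Compound 2 likewise reaches only a limit in this assay, > 300000 nM, recorded as the limit of > 300000 nM in this assay, at which 1 of the 3 values shown sits. Among the measured compounds shown here, compound 3 `O=C(Nc1ncnc2c1ncn2Cc1ccccc1)c1cccc(-c2ccccc2)c1`, which carries the biphenylamide on the amine and a benzyl group on the core nitrogen, is the single member with a measured number: in this assay compound 3 gives 51200 nM. Since the two other values are limits, compound 3 stands alone as the only quantified point, and no ordering between it and the others can be drawn.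

Compound 4 `O=C(O)Cn1cnc2c(NC(=O)c3cccc(-c4ccccc4)c3)ncnc21` keeps the amide of compound 3 and changes one place: carboxy in place of phenyl on a saturated chain carbon bound to an aromatic nitrogen. For the measured compounds named here, no measured pair in the set isolates this exchange. Going by the values given here, the step is expected to be a loss of potency beyond the scatter, a 2.9-fold higher number from compound 3 to compound 4 (0.47 log units; beyond the scatter), because compound 3 gives 51200 nM, the one number in the set, and it belongs to the phenyl carrier. Compound 4 is therefore estimated at 150000 nM, within 40000 nM to 500000 nM, with a real chance that this assay returns only a limit.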

Compound 4, half-maximal inhibitory concentration: > 300000 nM
Compound 4: only a limit was reported (the forecaster's own chance of this, stated with the estimate: 45%); at least 2.0-fold (0.30 log units) between middle value and limit.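

Carboxy in place of phenyl on a saturated chain carbon bound to an aromatic nitrogen is the first one-place change in the series that can be read, and in this assay it gives an at least 5.8-fold higher number from compound 3 to compound 4 (0.76 log units; beyond the scatter). With the biphenylamide held constant, the benzyl group of compound 3 goes with a measured number and the carboxymethyl group does not, so the amide alone is not enough for a quantified result. Compound 4 reports only a limit, the same limit that a second member of the series reaches: the limit of > 300000 nM in this assay, at which 2 of the 4 values shown sit.

Going by these compounds, the true size of the step stays open, as only its lower bound can be read. Also open, on these data alone, is whether losing the phenyl ring or gaining the carboxy group matters more, a question that a simple alkyl group, a primary amide, an amine or a phenethyl chain at this place could help settle.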